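Methoxy analogue of the benzyloxy compound 3

A few compounds are considered here, and "the series" means these few. Any claim that something is new, unique, unknown or untested is made for them only; others in the source may bear on it.

Compound 1 `O=c1c(Cc2coc3ccccc3c2=O)coc2ccccc12`, the unsubstituted parent of the series, gives 7770 nM in a functional assay on NUGC-3 cells (Homo sapiens) for antiproliferative activity, read by XTT assay; on this read-out lower numbers stand for stronger inhibition and higher numbers for weaker inhibition. Compound 2 `O=c1c(Cc2coc3cccc(O)c3c2=O)coc2ccccc12`, which carries a hydroxy on an aromatic carbon, gives 3270 nM in this assay; compound 3 `O=c1c(Cc2coc3cccc(OCc4ccccc4)c3c2=O)coc2ccccc12`, which carries a benzyloxy on that carbon, gives 7220 nM in this assay. Of the three numbers compound 3 stands second highest: it lies close to compound 1 and is set apart from compound 2 by a 2.2-fold higher number from compound 2 to compound 3 (0.34 log units; beyond the scatter). Going by the values given here, the single steps from the parent read a 2.4-fold lower number from compound 1 to compound 2 (0.38 log units; beyond the scatter) and a 1.1-fold lower number from compound 1 to compound 3 (0.03 log units; within the scatter).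

Compound 4 `COc1cccc2occ(Cc3coc4ccccc4c3=O)c(=O)c12` is still to be measured in this assay. The change from compound 3 is hydrogen in place of phenyl on a saturated chain carbon bound to an oxygen on an aromatic ring; cut one bond further out it reads benzyloxy to methoxy. Among the compounds with values here, the steps that bear on it are a 2.2-fold higher number from compound 2 to compound 3 (0.34 log units; beyond the scatter) and a 1.1-fold lower number from compound 1 to compound 3 (0.03 log units; within the scatter): the benzyl on the oxygen raised the number modestly, while benzyloxy against hydrogen stayed within the scatter. No methyl ether has been measured, so the expectation leans on these two steps only: a small step toward a lower number, a 1.4-fold lower number from compound 3 to compound 4 (0.16 log units; within the scatter), is expected. For compound 4 the estimated value is 5000 nM, within 2000 nM to 12000 nM.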

Compound 4, half-maximal inhibitory concentration: 3190 nM
Compound 4: the middle estimate sits 1.6-fold (0.20 log units) above what was measured; the range from low to high includes it.
By their numbers in this assay, from the lowest: compounds 4 and 2 (each within the scatter of the next); then compounds 3 and 1 (each within the scatter of the next).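

In this assay, cutting benzyloxy back to methoxy gives a 2.3-fold lower number from compound 3 to compound 4 (0.35 log units; beyond the scatter), so the cost of the benzyl group lies in the phenyl and not in having an ether on that oxygen. Methyl in place of the hydroxy hydrogen reads a 1.0-fold lower number from compound 2 to compound 4 (0.01 log units; within the scatter), so the free hydroxy hydrogen is not required at this position in this assay. Against the parent, methoxy reads a 2.4-fold lower number from compound 1 to compound 4 (0.39 log units; beyond the scatter), matching the hydroxy step a 2.4-fold lower number from compound 1 to compound 2 (0.38 log units; beyond the scatter), so two small oxygen substituents at this carbon go with the lower level, and compound 3 goes against any broader rule for oxygen substituents here.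

No measured property accounts for the effect of the phenyl. Open, on these data alone, is how far the lower level extends beyond methoxy, for example to ethoxy or a longer chain, and whether an amine or a carboxylic acid at this carbon would hold it.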